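Diyne ester series: vinyl to hydrogen on the chain end

The source may report more compounds than this note shows. Statements on the series, on what has been measured and on what is new or still open speak of the compounds shown alone.

Compound 1 `CCCCCCCC#CC#CCOCC(=O)O`: 7.5 ug/mL
Compound 2 `C=CCCCCCCCC#CC#CCOCC(=O)OC`: > 30 ug/mL

In a functional assay on SK-OV-3 cells (Homo sapiens) for cytotoxicity (on this read-out lower numbers stand for an effect already at smaller amounts and higher numbers for an effect only at larger amounts of compound), compound 1 gives 7.5 ug/mL. For compound 2 only a limit is known, > 30 ug/mL, and it sits at the limit of > 30 ug/mL in this assay, at which 1 of the 2 values shown sits. Compound 3 `CCCCCCCC#CC#CCOCC(=O)OC` is not yet measured; the change from compound 2 to compound 3 is hydrogen in place of vinyl on a saturated chain carbon, seven bonds along the chain from a triple-bonded carbon. Among the compounds with values here, no comparable step is measured here, so the size of the step is uncertain; a movement toward smaller numbers, modest in size, is expected, with a fair chance that compound 3 again reaches only a limit. For compound 3 the expected value is 20 ug/mL, between 7 ug/mL and 60 ug/mL, a step of an at least 1.5-fold lower number from compound 2 to compound 3 (0.17 log units; that floor lies within the scatter).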

Compound 3, concentration for half-maximal effect: 20.5 ug/mL
Compound 3: middle estimate off by 1.0-fold (0.01 log units), on the low side; the range from low to high includes it.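

In this assay, hydrogen in place of vinyl gives an at least 1.4-fold lower number from compound 2 to compound 3 (0.16 log units; that floor lies within the scatter), and the size of this step stays open on one side, since compound 2 is held only as a limit: the limit of > 30 ug/mL in this assay, at which 1 of the 3 values shown sits.

Within the data shown here, compound 3 also provides the first step read from two numbers: methyl in place of hydrogen on an oxygen next to a carbonyl group gives a 2.7-fold higher number from compound 1 to compound 3 (0.44 log units; beyond the scatter).

From the compounds shown here alone, the effect of a longer saturated chain at the chain end remains open. So does that of an amide in place of the methyl ester.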